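A few compounds are considered here, and "the series" means these few. Any claim that something is new, unique, unknown or untested is made for them only; others in the source may bear on it.

Working notes on the series.

Compound 1 `Cc1[nH]c2ccc(Cl)cc2c(=O)c1Br` gives 2.02 in a physicochemical assay for lipophilicity, at pH 7.4; a higher number here means a more lipophilic compound, a lower number a more polar compound. Compound 2 `Cc1[nH]c2ccc(F)cc2c(=O)c1Br` gives 1.61 in this assay; the change from compound 1 to compound 2 is fluoro in place of chloro on an aromatic carbon and its step is a number 0.41 log units lower from compound 1 to compound 2 (beyond the scatter). Compound 3 `CCCCC#Cc1c(C)[nH]c2ccc(Cl)cc2c1=O` gives 2.98 in this assay, the highest of the three numbers; its core differs from that of compound 1 by hex-1-yn-1-yl in place of bromo on an aromatic carbon, with a step of a number 0.96 log units higher from compound 1 to compound 3 (beyond the scatter).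

Compound 4 `CCCCC#Cc1c(C)[nH]c2ccc(F)cc2c1=O` has not yet been measured. It stands to compound 3 as compound 2 stands to compound 1: the change is fluoro in place of chloro on an aromatic carbon, and the place description is the same word for word as for the change from compound 1 to compound 2, so the change is taken as the same. Going by the values given here, the step from compound 3 to compound 4 in this assay is therefore expected to be about the size of the earlier one, a number 0.41 log units lower from compound 3 to compound 4 (beyond the scatter), resting on the single example a number 0.41 log units lower from compound 1 to compound 2 (beyond the scatter), with the different core of compound 3 allowed for in the range. Compound 4 is expected to give 2.57, between 2.25 and 2.9.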

Compound 4, distribution coefficient: 5.64
Compound 4: the middle estimate sits 3.07 log units below what was measured, outside the stated range (above it).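

Fluoro in place of chloro on an aromatic carbon does not carry from one core to the other in this assay: the earlier step is a number 0.41 log units lower from compound 1 to compound 2 (beyond the scatter), whereas the new one is a number 2.66 log units higher from compound 3 to compound 4 (beyond the scatter), so the direction reverses. Hex-1-yn-1-yl in place of bromo keeps its direction but not its size, with the earlier step of a number 0.96 log units higher from compound 1 to compound 3 (beyond the scatter) and the new one a number 4.03 log units higher from compound 2 to compound 4 (beyond the scatter), so neither change behaves as a fixed increment across these four compounds. Going by these compounds alone, this shows that the two changes do not combine additively here, but with only one pair on each core it does not show how either change behaves on another core, and nothing available bears on the reason for the difference.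

On these data alone, whether the fluoro and chloro step stays large and upward with a longer chain in place of hex-1-yn-1-yl remains open. So does the size of that step in this assay when an amine or a carboxylic acid stands in that place.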